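The source may report more compounds than this note shows. Statements on the series, on what has been measured and on what is new or still open speak of the compounds shown alone.

Working notes on the thiocarbamate series

Compound 1 `Cc1ccc2c(=O)c(CSC(=S)N3CCCCC3)coc2c1` is tested in a functional assay on HeLa cells (Homo sapiens) for antiproliferative activity, read by MTT assay, with a stated time of 72 h; on this read-out lower numbers stand for stronger inhibition and higher numbers for weaker inhibition. In this assay compound 1 gives > 25000 nM, which is a limit of the assay and not a number. Compound 3 `O=c1c(SC(=S)N2CCCCC2)coc2ccccc12` gives 9000 nM in this assay. Compound 2 `CCOC(=O)c1cc(=O)c2cc(CSC(=S)N(C(C)C)C(C)C)ccc2o1` is the reference point for the step considered here. In this assay compound 2 gives > 25000 nM, again a limit of the assay rather than a measured number. For the measured compounds named here, compound 2 therefore stands at the limit of > 25000 nM in this assay, at which 2 of the 3 values shown sit, so nothing more than an upper bound on its potency is known, and no measured step to any other compound can be stated.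

Compound 4 `CCOC(=O)c1cc(=O)c2cc(CSC(=S)N(C)c3ccccc3)ccc2o1` keeps the whole of compound 2 except the amine attached to the thiocarbonyl carbon: methyl(phenyl)amino in place of diisopropylamino on a thiocarbonyl carbon. Going by the values given here, no measured pair changes only this position, so the size of the step has no direct precedent. With compound 2 at the limit of > 25000 nM in this assay, at which 2 of the 3 values shown sit, the expected step from compound 2 to compound 4 is put at an at least 1.2-fold lower number from compound 2 to compound 4 (0.09 log units; that floor lies within the scatter), that is, no change beyond the usual scatter in either direction, and a fair chance that this assay again returns only a limit. The estimate for compound 4 in this assay is 20000 nM, with a range from 7000 nM to 60000 nM.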

Compound 4, half-maximal inhibitory concentration: 18100 nM
Estimate against measurement, compound 4: 1.1-fold (0.04 log units) above, within the range that was stated.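

In this assay, replacing diisopropylamino with methyl(phenyl)amino on a thiocarbonyl carbon gives an at least 1.3-fold lower number from compound 2 to compound 4 (0.14 log units; that floor lies within the scatter). Compound 2 remains a limit of the assay and not a number: the limit of > 25000 nM in this assay, at which 2 of the 4 values shown sit. Compound 4, at 18100 nM, gives this position its first measured value with the rest of compound 2 kept, showing that a number can be read here. Going by these compounds, the step printed is only a floor that does not go beyond the scatter, and the true size of the change remains unknown.

On these data alone, the true distance between compound 2 and compound 4 stays open, as does whether the step follows the loss of diisopropylamino or the entry of the aromatic ring in methyl(phenyl)amino, and the two compounds cannot separate these. Also open, as far as these compounds go, is how a dimethylamino group, which carries no ring, or a morpholine ring would stand on the same thiocarbonyl carbon with the rest of compound 2 unchanged, and such a pair would show whether the ring itself matters.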